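Benzoyl Removal and Tolerance in Vero Cells

The source may report more compounds than this note shows. Statements on the series, on what has been measured and on what is new or still open speak of the compounds shown alone.

Compound 1 `COc1cccc(OC)c1/C=N/NC(=O)c1ccncc1` and compound 2 `COc1cccc(OC)c1/C=N/N(C(=O)c1ccccc1)C(=O)c1ccncc1` share a core and differ by one change: hydrogen in place of benzoyl on an amide-type nitrogen. In an ADME assay on Vero cells (Chlorocebus sabaeus) for cytotoxicity (a higher number here means that more compound is tolerated, a lower number that less compound is tolerated), compound 2 gives 100 ug/mL, and compound 1 gives 100 ug/mL, so the step of no change at the digits printed from compound 2 to compound 1 (within the scatter). Compound 3 `CSc1ccc(/C=N/N(C(=O)c2ccccc2)C(=O)c2ccncc2)cc1` is built on another core; how that core differs from the core of compound 2 is not broken down here. In this assay compound 3 gives >= 100 ug/mL, which is a limit of the assay and not a number, as shown by the limit of >= 100 ug/mL in this assay, at which 1 of the 3 values shown sits. Compound 4 `CSc1ccc(/C=N/NC(=O)c2ccncc2)cc1` has not yet been measured and comes from compound 3 by the same change: hydrogen in place of benzoyl on an amide-type nitrogen. The expected step in this assay is a number no higher from compound 3 to compound 4 (the limit leaves the size open), resting on the earlier measured step of no change at the digits printed from compound 2 to compound 1 (within the scatter). Compound 4 is therefore estimated at 100 ug/mL, between 50 ug/mL and 100 ug/mL.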

Compound 4, minimum cytotoxic concentration: >= 100 ug/mL
Compound 4 was reported as a limit (the forecaster's own chance of this, stated with the estimate: 50%); the middle value sits exactly at the limit.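

No step can be read from compound 3 to compound 4, because both results are limits of the assay and not numbers: the limit of >= 100 ug/mL in this assay, at which 2 of the 4 values shown sit.

The compounds shown leave open whether hydrogen in place of benzoyl changes the result in this assay on the core of compound 3.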